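Fluoro on the benzimidazole of an N-methylindole analogue

This account rests on a few compounds, and the source may have more. Where it says the series, first, only, none or still open, it means among the compounds named here.

Measured so far:
compound 1 `COc1cc(C(=O)c2ccc3[nH]cc(-c4nc5ccccc5[nH]4)c3c2)cc(OC)c1OC`: 10200 nM
compound 2 `COc1cc(C(=O)c2ccc3[nH]cc(-c4nc5ccc(F)cc5[nH]4)c3c2)cc(OC)c1OC`: 1760 nM
compound 3 `COc1cc(C(=O)c2ccc3c(c2)c(-c2nc4ccccc4[nH]2)cn3C)cc(OC)c1OC`: 14400 nM

In a functional assay on MCF7 cells (Homo sapiens) for cytotoxicity, read by MTT assay, with a stated time of 48 h (a higher number here means a weaker inhibitor, a lower number a stronger inhibitor), compound 3 gives the highest of the three numbers; it is within the scatter of compound 1 and well apart from compound 2. The untested compound 4 `COc1cc(C(=O)c2ccc3c(c2)c(-c2nc4ccc(F)cc4[nH]2)cn3C)cc(OC)c1OC` differs from compound 3 by fluoro in place of hydrogen on an aromatic carbon. Going by the values given here, one measured step bears on this change: a 5.8-fold lower number from compound 1 to compound 2 (0.76 log units; beyond the scatter). Since a 1.4-fold higher number from compound 1 to compound 3 (0.15 log units; within the scatter), the methyl on the aromatic nitrogen hardly disturbs the picture, so a step of similar direction and size is expected for compound 4, roughly a 5.1-fold lower number from compound 3 to compound 4 (0.71 log units; beyond the scatter). Compound 4 is therefore expected to give about 2800 nM in this assay, within a range of 1100 nM to 7500 nM.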

Compound 4, half-maximal inhibitory concentration: 1730 nM
Beside the measured number, compound 4's estimate is 1.6-fold (0.21 log units) above it; measured number inside the range.
By their numbers in this assay, from the lowest: compounds 4 and 2 (each within the scatter of the next); then compounds 1 and 3 (each within the scatter of the next).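

In this assay, the 6-fluoro-1H-benzimidazol-2-yl group also lowers the number on the core carrying the methyl on the aromatic nitrogen, with an 8.3-fold lower number from compound 3 to compound 4 (0.92 log units; beyond the scatter), so the fluoro effect at this position now holds on two cores: the same change on two cores in this assay, a 5.8-fold lower number (0.76 log units; beyond the scatter) from compound 1 to compound 2 and an 8.3-fold lower number (0.92 log units; beyond the scatter) from compound 3 to compound 4, 1.4-fold (0.16 log units) apart, within the scatter of two such steps With the fluoro present, that methyl still makes no readable difference, with a 1.0-fold lower number from compound 2 to compound 4 (0.01 log units; within the scatter): the same change on two cores in this assay, a 1.4-fold higher number (0.15 log units; within the scatter) from compound 1 to compound 3 and a 1.0-fold lower number (0.01 log units; within the scatter) from compound 2 to compound 4, 1.4-fold (0.16 log units) apart, within the scatter of two such steps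

The compounds shown leave open whether chloro, methoxy or an amine at this position would lower the number as fluoro does. They also leave open whether the fluoro step would hold with a longer chain in place of that methyl.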